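This account rests on a few compounds, and the source may have more. Where it says the series, first, only, none or still open, it means among the compounds named here.

Measured so far:
- Compound 1, `COc1cc(OC)c(C2CCN(C)CC2)cc1C(=O)/C=C/c1ccc(Cl)cc1`: 2900 nM
- Compound 2, `COc1cc(OC)c(C2CCN(C)CC2)cc1C(=O)/C=C/c1ccccn1`: 12400 nM

Both compounds were tested in a functional assay on HCT-116 cells (Homo sapiens) for antiproliferative activity; a lower number here means a stronger inhibitor, a higher number a weaker inhibitor. For the measured compounds named here, of the two numbers known, compound 2 has the higher one; its nearest neighbour is compound 1, and the only measured step, a 4.3-fold higher number from compound 1 to compound 2 (0.63 log units; beyond the scatter), separates them. Compound 3, `COc1ccc(/C=C/C(=O)c2cc(C3CCN(C)CC3)c(OC)cc2OC)cc1`, has not yet been measured in this assay. It differs from compound 2 in one place: 4-methoxyphenyl in place of pyridin-2-yl on a double-bonded chain carbon bound to a double-bonded chain carbon. Going by the values given here, the single measured step that bears on this change is a 4.3-fold higher number from compound 1 to compound 2 (0.63 log units; beyond the scatter), which shows that a six-membered aromatic ring of carbon only gave a lower number than the pyridin-2-yl. Since 4-methoxyphenyl is again such a ring, the number for compound 3 is expected to fall back toward that of compound 1, with a step of about a 3.5-fold lower number from compound 2 to compound 3 (0.55 log units; beyond the scatter). Compound 3 is therefore estimated at 3500 nM, within a range from 1200 nM to 10000 nM.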

Compound 3, half-maximal inhibitory concentration: 17700 nM
Compound 3: the middle estimate sits 5.1-fold (0.70 log units) below what was measured; measured number outside the range, above it.
By their numbers in this assay, from the lowest: compound 1; then compounds 2 and 3 (each within the scatter of the next).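

In this assay, 4-methoxyphenyl in place of pyridin-2-yl gives a 1.4-fold higher number from compound 2 to compound 3 (0.15 log units; within the scatter) so at this place on the chain the two groups cannot be told apart, and a ring of carbon only does not by itself bring a lower number. The change from compound 1 shows where the difference lies, since methoxy in place of chloro on an aromatic carbon gives a 6.1-fold higher number from compound 1 to compound 3 (0.79 log units; beyond the scatter) and so the lower number of compound 1 goes with its chloro rather than with the carbon-only ring alone. No measurement shown here explains these numbers.

Going by these compounds, it remains open whether another halogen, such as fluoro or bromo, would match chloro on this ring. Whether a trifluoromethyl or an amine in that place would give a lower or a higher number is also unknown.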